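The compounds below may be only part of what the source reports. "The series", "measured", "known", "first", "only" and "open" are said of these compounds alone.

Compounds measured in an assay on SH-EP1 cells for agonist activity at Neuronal acetylcholine receptor; alpha4/beta2 (Homo sapiens), read by FLIPR and calcium flux; a higher number here means a larger maximal response, a lower number a smaller maximal response:
Compound 1 `CC(=O)N1CC2CC(C1)N2`: 94%
Compound 2 `O=C([C@@H]1C[C@@H]1F)N1CC2CC(C1)N2`: 120%
Compound 3 `O=C([C@@H]1C[C@H]1F)N1CC2CC(C1)N2`: 110%

Compound 3 stands second highest of the three. Its nearest neighbour is compound 2, a number 10 percentage points lower from compound 2 to compound 3 (within the scatter); this closeness sits with the fact that one of compounds 2 and 3 is drawn with a defined configuration and the other without, at the place where they differ. Its furthest neighbour is compound 1, a number 16 percentage points higher from compound 1 to compound 3 (beyond the scatter).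

Compound 4 `C[C@@H]1C[C@@H]1C(=O)N1CC2CC(C1)N2` differs from compound 3 in one place: a group of 4 heavy atoms (4 carbon; one three-membered non-aromatic ring of carbon only) in place of a group of 4 heavy atoms (3 carbon, 1 fluorine; one three-membered non-aromatic ring of carbon only), on a carbonyl carbon.

Within the data shown here, two measured steps bear on this. Both a number 26 percentage points higher from compound 1 to compound 2 (beyond the scatter) and a number 16 percentage points higher from compound 1 to compound 3 (beyond the scatter) show that a 2-fluorocyclopropyl in place of methyl on the carbonyl carbon raised the largest response modestly. Among the measured compounds shown here, no measured pair swaps the fluorine of that ring for a carbon, so nothing shows whether the gain rests on the ring or on the fluorine. Since the three-membered ring is kept in compound 4, the expected step of a number 5 percentage points lower from compound 3 to compound 4 (within the scatter) is small, at most a slight drop, within the scatter. Compound 4 is therefore estimated at 105%, with a range from 85% to 125%.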

Compound 4, largest response reached (Emax), in percent of the reference or control that the assay uses: 88%
For compound 4 the middle estimate is 17 percentage points above the measured one; the range from low to high includes it.
By their numbers in this assay, from the lowest: compounds 4 and 1 (each within the scatter of the next); then compounds 3 and 2 (each within the scatter of the next).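

In this assay, the fluorine proves to matter at this place on the carbonyl carbon: with a carbon in its stead on the three-membered ring, the response falls, a number 22 percentage points lower from compound 3 to compound 4 (beyond the scatter) and a number 32 percentage points lower from compound 2 to compound 4 (beyond the scatter). The ring without fluorine does not keep the gain seen over the methyl group, a number 6 percentage points lower from compound 1 to compound 4 (within the scatter), so that gain rests on the 2-fluorocyclopropyl group and not on the ring alone. Nothing measured here gives a cause for this difference.

Going by these compounds, whether chlorine or a hydroxyl group on the ring would hold the response stays open, as does whether fluorine would do so without the ring, as in a fluoromethyl group on the carbonyl carbon. The compounds shown also leave open how other configurations of the all-carbon ring group compare.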